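This account rests on a few compounds, and the source may have more. Where it says the series, first, only, none or still open, it means among the compounds named here.

Working notes on the thiosemicarbazone series. Among the measured compounds shown here, compound 1 `Fc1cccc(NC(=S)N/N=C/c2ccc3ccccc3n2)c1` is tested in a functional assay on HL-60 cells (Homo sapiens) for antiproliferative activity, read by sulforhodamine B assay, with a stated time of 72 h (a higher number here means a weaker inhibitor, a lower number a stronger inhibitor), and gives 43800 nM, the highest of the two numbers so far. Compound 3 `CN(C)C(=S)N/N=C/c1nc2ccccc2s1` gives 3680 nM in this assay, a gap beyond the scatter. Compound 2 `Cc1csc2sc(/C=N/NC(N)=S)c(C)c12` reaches only (the limit of > 100000 nM in this assay, at which 1 of the 3 values shown sits), a limit of the assay rather than a number, and compound 2 is recorded as > 100000 nM in this assay. Compound 4 `S=C(N/N=C/c1ccc2ccccc2n1)Nc1cccc(Br)c1` has not been measured. It differs from compound 1 by bromo in place of fluoro on an aromatic carbon. For the measured compounds named here, no step between measured compounds speaks to this change, so the expected step from a 1.5-fold lower number from compound 1 to compound 4 (0.16 log units; within the scatter) is small, within the scatter. Compound 4 is expected to give about 30000 nM in this assay, within 10000 nM to 90000 nM.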

Compound 4, half-maximal inhibitory concentration: 53800 nM
The estimate for compound 4 lay 1.8-fold (0.25 log units) below the measured number; measured number inside the range.
By their numbers in this assay, from the lowest: compound 3; then compounds 1 and 4 (each within the scatter of the next). At a limit, above all of these: compound 2.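

In this assay, among the compounds shown here, the exchange of 3-fluorophenyl for 3-bromophenyl gives a 1.2-fold higher number from compound 1 to compound 4 (0.09 log units; within the scatter), the only step that isolates a single place. At this position, bromo and fluoro are not told apart by this read-out. No measured property in the data bears on this step. On these data alone, whether an amine, a carboxylic acid or a methoxy group at this position would separate from the two halogens remains open. As far as these compounds go, whether the same exchange reads alike on another core also remains open.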